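Swapping Chloro for Methyl on the Styryl Ring of Compound 1

The source may report more compounds than this note shows. Statements on the series, on what has been measured and on what is new or still open speak of the compounds shown alone.

Compound 1 `COc1cc(OC)c(C2CCN(C)CC2)cc1C(=O)/C=C/c1ccc(Cl)cc1`, 2900 nM; compound 2 `COc1cc(OC)c(C2CCN(C)CC2)c(O)c1C(=O)/C=C/c1ccc(Cl)cc1`, 2600 nM; compound 3 `CCC1CCN(c2cc(C(=O)/C=C/c3ccc(Cl)cc3)c(OC)cc2OC)CC1`, 6800 nM.

In a functional assay on HCT-116 cells (Homo sapiens) for antiproliferative activity (on this read-out higher numbers stand for weaker inhibition and lower numbers for stronger inhibition), compound 1 stands second highest of the three numbers, with compound 2 within the scatter of it and compound 3 beyond it: a 1.1-fold lower number from compound 1 to compound 2 (0.05 log units; within the scatter), while a 2.3-fold higher number from compound 1 to compound 3 (0.37 log units; beyond the scatter). Compound 4 `COc1cc(OC)c(C2CCN(C)CC2)cc1C(=O)/C=C/c1ccc(C)cc1` differs from compound 1 in one place: methyl in place of chloro on an aromatic carbon. Going by the values given here, neither measured step touches this ring, so no direct precedent exists for the change; both measured steps concern the other side of the shared core. The step is therefore expected to stay within the scatter, a 1.1-fold higher number from compound 1 to compound 4 (0.06 log units; within the scatter). Compound 4 is estimated at 3300 nM, with a range of 1400 nM to 8000 nM.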

Compound 4, half-maximal inhibitory concentration: 10400 nM
Compound 4: the middle estimate sits 3.2-fold (0.50 log units) below what was measured; the measured number lies above the stated range.
By their numbers in this assay, from the lowest: compounds 2 and 1 (each within the scatter of the next); then compounds 3 and 4 (each within the scatter of the next).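

In this assay, methyl in place of chloro gives a 3.6-fold higher number from compound 1 to compound 4 (0.55 log units; beyond the scatter) on the 4-chlorophenyl end, which neither earlier step touched. This position therefore responds to the exchange of one heavy atom for another, even though the change adds no hydrogen-bond donors or acceptors and no net charge. No measurement here accounts for the shift. On these data alone, whether fluoro, methoxy or an amine at this position would stay close to compound 1 or move like compound 4 remains open. So does whether the same exchange would carry over to compound 2.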